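The source may hold more compounds than are shown below. What is called first, only, known or untested is meant among the compounds shown, and "the series" means these compounds.

In a functional assay on UACC-62 cells (Homo sapiens) (on this read-out lower numbers stand for stronger inhibition of growth and higher numbers for weaker inhibition of growth), compound 1 (`O=S(=O)(/C=C/c1ccc(Cl)c(Cl)c1)Cc1ccc(Nc2ncnc3ccccc23)cc1`) gives 21000 nM, compound 2 (`O=S(=O)(/C=C/c1ccc(F)cc1Cl)Cc1ccc(Nc2ncnc3ccccc23)cc1`) gives 100000 nM and compound 3 (`O=S(=O)(/C=C/c1ccc(Cl)c(Cl)c1)Cc1ccc(Nc2ncnc3ccc(Br)cc23)cc1`) gives 30000 nM. Compound 3 thus stands within the scatter of compound 1, while compound 2 carries the highest number of the three.

Compound 4 (`O=S(=O)(/C=C/c1ccc(O)cc1)Cc1ccc(Nc2ncnc3ccc(Br)cc23)cc1`) keeps the core of compound 3 but has 4-hydroxyphenyl in place of 3,4-dichlorophenyl on a double-bonded chain carbon bound to a double-bonded chain carbon.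

Among the measured compounds shown here, the nearest guide is the one measured swap of this same group, which gave a 4.8-fold higher number from compound 1 to compound 2 (0.68 log units; beyond the scatter), a modest step beyond the scatter. The other measured step, a 1.4-fold higher number from compound 1 to compound 3 (0.15 log units; within the scatter), lies within the scatter and concerns the bromo group, which compound 4 retains. For the measured compounds named here, no measured compound carries a hydroxy group, so the guide is loose.

A modest move toward weaker inhibition of growth in this assay is expected, with an estimated size of a 1.7-fold higher number from compound 3 to compound 4 (0.22 log units; within the scatter). For compound 4 the estimated value is 50000 nM, with an expected range of 17000 nM to 100000 nM.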

Compound 4, concentration for 50% growth inhibition: 28000 nM
The estimate for compound 4 lay 1.8-fold (0.25 log units) above the measured number, within the range that was stated.
By their numbers in this assay, from the lowest: compounds 1, 4 and 3 (each within the scatter of the next); then compound 2.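

In this assay, 4-hydroxyphenyl in place of 3,4-dichlorophenyl on a double-bonded chain carbon bound to a double-bonded chain carbon gives a 1.1-fold lower number from compound 3 to compound 4 (0.03 log units; within the scatter), which lies within the scatter. On the core of compound 3, this place therefore tolerates the exchange of both chlorine atoms for a single hydroxy group without a step that can be told from the scatter. Among the compounds shown here, the only earlier change at this place, a 4.8-fold higher number from compound 1 to compound 2 (0.68 log units; beyond the scatter), lay beyond the scatter, so the two changes show that replacing 3,4-dichlorophenyl here does not always carry the same outcome.

From the compounds shown here alone, whether a methoxy group, an amine or a carboxylic acid in place of the hydroxy group would also stay within the scatter of compound 3 remains open, as does the result of the hydroxy group on the core of compound 1. No measurement at hand accounts for the difference in size between the two changes.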